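The source may report more compounds than this note shows. Statements on the series, on what has been measured and on what is new or still open speak of the compounds shown alone.

Compound 3 `Cc1occc1-c1nnc(SCC(=O)NN2CCc3ccccc32)n1Cc1ccco1` gives in a functional assay on CHO cells for antagonist activity at Orexin/Hypocretin receptor type 1 (Homo sapiens), read by FLIPR and calcium flux (a higher number here means a weaker inhibitor, a lower number a stronger inhibitor), only a limit, > 15800 nM. Compound 1 `Cc1cccc(NC(=O)CSc2nnc(-c3ccoc3C)n2Cc2ccco2)c1C` likewise reaches only a limit in this assay, > 15800 nM. For the measured compounds named here, compound 2 `CC(=O)c1cccc(NC(=O)CSc2nnc(-c3ccoc3C)n2Cc2ccco2)c1` gives 3160 nM, the single numbered value among the three, the other two resting at the limit of > 15800 nM in this assay, at which 2 of the 3 values shown sit. The step of an at least 5.0-fold lower number from compound 1 to compound 2 (0.69 log units; beyond the scatter) is readable, whereas a step that the two limits leave unreadable from compound 1 to compound 3 and an at least 5.0-fold higher number from compound 2 to compound 3 (0.69 log units; beyond the scatter) place compound 3 at the weak end of the set. Compound 4 `Cc1occc1-c1nnc(SCC(N)=O)n1Cc1ccco1` differs from compound 3 by hydrogen in place of 2,3-dihydro-1H-indol-1-yl on an amide-type nitrogen. The measured steps all swap one substituent for another on that nitrogen; none removes it entirely. The step that the limit leaves unreadable from compound 3 to compound 4 is expected to stay within the scatter. Compound 4 is estimated at 20000 nM, between 8000 nM and 60000 nM, most probably again as a limit.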

Compound 4, inhibition constant: > 15800 nM
Compound 4 was reported as a limit; the forecaster's own chance of this, stated with the estimate: 80%; the middle value lies beyond the limit too.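

With hydrogen on the amide-type nitrogen, compound 4 also reaches only a limit in this assay, > 15800 nM. Removing the substituent altogether therefore does not match compound 2: the result is an at least 5.0-fold higher number from compound 2 to compound 4 (0.69 log units; beyond the scatter), and among the four compounds only the 3-acetylphenyl group gives a numbered value. The steps to compound 4 from compound 1 and from compound 3 cannot be read, as both ends of each are limits: the limit of > 15800 nM in this assay, at which 3 of the 4 values shown sit.

As far as these compounds go, it remains open whether the acetyl group itself accounts for the difference between compound 2 and compound 1. A phenyl group carrying a carboxylic acid or an amine in place of the acetyl could test this.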